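The source may report more compounds than this note shows. Statements on the series, on what has been measured and on what is new or still open speak of the compounds shown alone.

Compound 1, `Nc1ncnc2c1nc(NCc1ccccc1Cl)n2[C@@H]1O[C@H](CO)[C@@H](O)[C@H]1O`, is the only one of the three measured compounds for which an assay on COS-7 cells for inhibition of sodium/nucleoside cotransporter 2 (Homo sapiens), read by scintillation counting, in the presence of a further agent that is not named here (a lower number here means a stronger inhibitor, a higher number a weaker inhibitor), gives a number: compound 1 shows 5700 nM. Compound 2, `Nc1ncnc2c1ncn2[C@@H]1O[C@H](COC(=O)NCc2ccccc2)[C@@H](O)[C@H]1O`, reaches only a limit of the assay, > 100000 nM. Compound 3, `CNC(=O)OC[C@H]1O[C@@H](n2cnc3c(N)ncnc32)[C@H](O)[C@@H]1O`, likewise stops at a limit, > 100000 nM. The step that the two limits leave unreadable from compound 2 to compound 3 therefore cannot be read, and because of the limit of > 100000 nM in this assay, at which 2 of the 3 values shown sit, compound 1 stands alone on the numbers. Compound 4, `COc1ccccc1CNc1nc2c(N)ncnc2n1[C@@H]1O[C@H](CO)[C@@H](O)[C@H]1O`, differs from compound 1 by methoxy in place of chloro on an aromatic carbon. Going by the values given here, no measured step touches this change, so the step is estimated as a 1.1-fold higher number from compound 1 to compound 4 (0.02 log units; within the scatter), nothing beyond the usual scatter. Compound 4 is thus expected to give about 6000 nM, within a range of 2000 nM to 20000 nM.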

Compound 4, half-maximal inhibitory concentration: > 100000 nM
Compound 4: only a limit was reported; the forecaster's own chance of this, stated with the estimate: 10%; at least 16-fold (1.22 log units) between middle value and limit.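

In this assay, going by these compounds alone, methoxy in place of chloro on this aromatic carbon gives an at least 17-fold higher number from compound 1 to compound 4 (1.24 log units; beyond the scatter), so the number for compound 1 depends strongly on the group at this place, which no earlier step could show. Compound 4 ends at a limit, so this step has only a lower bound and no full size: the limit of > 100000 nM in this assay, at which 3 of the 4 values shown sit.

The compounds shown leave open whether the loss follows from methoxy entering or from chloro leaving; fluoro, bromo or methyl here could separate the two. Going by these compounds, a plain benzyl group also remains open.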